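The source may report more compounds than this note shows. Statements on the series, on what has been measured and on what is new or still open speak of the compounds shown alone.

In a functional assay on A-375 cells (Homo sapiens) for antiproliferative activity, read by MTT assay, with a stated time of 72 h (a higher number here means a weaker inhibitor, a lower number a stronger inhibitor), compound 1 `O=C1COc2ccc(-c3cccc(NS(=O)(=O)c4ccc(F)cc4)c3)cc2N1` gives 20100 nM and compound 2 `COc1cccc(N2C(=O)COc3ccc(-c4cnc5ccccc5c4)cc32)c1` gives 23600 nM. Going by the values given here, these two numbers lie within the usual scatter of each other, so compound 1 stands level with the only other measured compound. Compound 3 `O=C1COc2ccc(-c3cccc(NS(=O)(=O)c4ccc(F)cc4)c3)cc2N1C1CC1` keeps the core of compound 1 and changes one place: cyclopropyl in place of hydrogen on an amide-type nitrogen in a ring. Among the compounds with values here, no measured pair differs in one place alone, so there is no direct guide to the size of this step. Compound 2 differs from compound 1 in more than one place and also lacks the amide hydrogen. Compound 2 gives 23600 nM, so no large shift in this assay is expected. The estimated step is a 1.4-fold lower number from compound 1 to compound 3 (0.16 log units; within the scatter), small, toward a lower number and not clearly beyond the scatter. For compound 3 the expected value is 14000 nM, with an estimated range of 4000 nM to 45000 nM.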

Compound 3, half-maximal inhibitory concentration: > 40000 nM
Compound 3: no number, only a limit; the forecaster's own chance of this, stated with the estimate: 15%; middle value at least 2.8-fold (0.45 log units) away from the limit.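

In this assay, compound 3 carries only a limit of the assay, > 40000 nM, and not a number. Going by these compounds alone, this gives the first direct reading at this position, an at least 1.9-fold higher number from compound 1 to compound 3 (0.29 log units; that floor lies within the scatter): cyclopropyl in place of the amide hydrogen on the amide-type nitrogen in a ring brought no gain in this assay, and the data exclude the lower number that a gain would have given. The step can be stated only as a floor because it rests on a limit: the limit of > 40000 nM in this assay, at which 1 of the 3 values shown sits.

The compounds shown leave open how far the true number for compound 3 lies from that of compound 1. They also leave open whether a methyl group, an ethyl chain or a chain ending in an amine on this same nitrogen would behave as cyclopropyl does.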